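Adding One Chloro to Compound 2

The compounds below may be only part of what the source reports. "The series", "measured", "known", "first", "only" and "open" are said of these compounds alone.

In an ADME assay on T29 cells (Homo sapiens) for cytotoxicity, read by sulforhodamine B assay, with a stated time of 3 days (on this read-out higher numbers stand for weaker inhibition and lower numbers for stronger inhibition), compound 1 `O=Cc1cn(Cc2ccc(Cl)cc2Cl)c2ccccc12` gives > 31600 nM, which is a limit and not a number. Compound 2 `OCc1cn(Cc2ccc(Cl)cc2)c2ccccc12` gives > 31600 nM, also a limit and not an exact value. What is known so far is the limit of > 31600 nM in this assay, at which 2 of the 2 values shown sit. Compound 3 `OCc1cn(Cc2ccc(Cl)cc2Cl)c2ccccc12` is still unmeasured and differs from compound 2 by chloro in place of hydrogen on an aromatic carbon, with chloro in place of hydrogen on an aromatic carbon. Going by the values given here, no measured step shows what this change does. The estimated step that the limit leaves unreadable from compound 2 to compound 3 is expected to stay within the usual scatter, with no clear direction. Compound 3 is expected at 40000 nM, with an estimated range from 15000 nM to 100000 nM.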

Compound 3, half-maximal inhibitory concentration: > 31600 nM
Compound 3 ended at the assay's limit; the forecaster's own chance of this, stated with the estimate: 80%; the middle value does not contradict the limit.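

Compound 1, compound 2 and compound 3 all sit at a limit, so neither step to compound 3 can be read. Going by these compounds, what chloro in place of hydrogen, or hydroxymethyl in place of formyl, does here stays open.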